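Methoxy removal on the aryl ring of pyrazolyl enones

The source may report more compounds than this note shows. Statements on the series, on what has been measured and on what is new or still open speak of the compounds shown alone.

Compound 1 `COc1cc(-c2cc(/C=C/C(=O)c3ccc(N)cc3)[nH]n2)cc(OC)c1OC` gives 7% in a functional assay on MDA-MB-231 cells (Homo sapiens) for cytotoxicity, read by sulforhodamine B assay, with a stated time of 48 h, tested at 10 uM; a lower number here means a stronger effect, a higher number a weaker effect of the compound at the concentration tested. Compound 2 `COc1ccc(-c2cc(/C=C/C(=O)c3ccc(N)cc3)[nH]n2)cc1OC` gives 24% in this assay. The change between these two, (hydrogen in place of methoxy on an aromatic carbon), produced a number 17 percentage points higher from compound 1 to compound 2 (beyond the scatter).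

Compound 3 `COc1cc(C(=O)/C=C/c2cc(-c3cc(OC)c(OC)c(OC)c3)n[nH]2)cc(OC)c1OC` is built on another core; how the core of compound 3 differs from the core of compound 1 is not broken down here. In this assay compound 3 gives -53%, the lowest of the three numbers, with both other compounds beyond the scatter above it.

Compound 4 `COc1ccc(-c2cc(/C=C/C(=O)c3cc(OC)c(OC)c(OC)c3)[nH]n2)cc1OC` has not yet been measured. It differs from compound 3 by hydrogen in place of methoxy on an aromatic carbon, the same change as between compound 1 and compound 2, and the surroundings of the place are described in the same words. This change occurs only twice among the compounds shown, so the one measured step is the only guide, and whether it carries over to the core of compound 3 is untested.

In this assay a step of a number 17 percentage points higher from compound 3 to compound 4 (beyond the scatter) is expected. This rests on compound 1 and compound 2, whose step was a number 17 percentage points higher from compound 1 to compound 2 (beyond the scatter). For compound 4 the expected value is -36%, with an expected range from -62% to -8%.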

Compound 4, a percentage reported as activity, at one concentration (the size of the read-out at that concentration, not a potency): 11%
Compound 4: middle estimate off by 47 percentage points, on the low side; the whole stated range lies below it.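

In this assay, replacing methoxy with hydrogen on the aromatic carbon gives a number 64 percentage points higher from compound 3 to compound 4 (beyond the scatter), so the direction of the step carries from the core of compound 1 to the core of compound 3, but its size does not: the same change on two cores in this assay, a number 17 percentage points higher (beyond the scatter) from compound 1 to compound 2 and a number 64 percentage points higher (beyond the scatter) from compound 3 to compound 4, 47 percentage points apart, beyond the scatter of two such steps. The change therefore cannot be treated as a fixed increment in this series, and on these two pairs its size depends on the core that carries it. Two pairs show no rule for other cores and give no reason for the gap, and each read-out is the size of the effect at one concentration, not a potency.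

The compounds shown leave open whether the larger step on the core of compound 3 is particular to methoxy or would also appear with another group at this place, such as hydroxy, chlorine or ethoxy. They also leave open what happens on either core when a further methoxy is replaced by hydrogen.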